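The compounds below may be only part of what the source reports. "The series", "measured", "known", "first", "only" and "open" are said of these compounds alone.

Measured in a functional assay on MCF cells (Homo sapiens) for antiproliferative activity, with a stated time of 72 h; a lower number here means a stronger inhibitor, a higher number a weaker inhibitor:
- compound 1 `OC[C@H]1O[C@@H](n2cnc3c(NCc4cccc(F)c4)ncnc32)[C@H](O)[C@@H]1O`: 15300 nM
- compound 2 `OC[C@H]1O[C@@H](n2cnc3c(NCc4ccccc4Cl)ncnc32)[C@H](O)[C@@H]1O`: > 166000 nM, a limit
- compound 3 `Cc1cccc(CNc2ncnc3c2ncn3[C@@H]2O[C@H](CO)[C@@H](O)[C@H]2O)c1`: > 166000 nM, a limit

Compound 3 has no numeric value in this assay, only the limit > 166000 nM. That limit is shared across the small set, as the limit of > 166000 nM in this assay, at which 2 of the 3 values shown sit, shows. Compound 4 `OC[C@H]1O[C@@H](n2cnc3c(NCc4ccc(Cl)cc4Cl)ncnc32)[C@H](O)[C@@H]1O` carries 2,4-dichlorophenyl in place of 3-methylphenyl on a saturated chain carbon bound to a nitrogen on an aromatic ring.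

Among the measured compounds shown here, the closest precedent is the chlorinated compound 2, reached through an at least 10-fold higher number from compound 1 to compound 2 (1.03 log units; beyond the scatter). The other measured change gave a similarly large loss, an at least 10-fold higher number from compound 1 to compound 3 (1.03 log units; beyond the scatter). Between the two limits, the comparison is a step that the two limits leave unreadable from compound 2 to compound 3. Only compound 1 goes against the tendency to sit at the limit, and it alone carries 3-fluorophenyl.

A clear gain is therefore not expected, and compound 4 will most likely also be reported only as a limit. The expected change is small, at most a modest move towards a lower number: an at least 1.3-fold lower number from compound 3 to compound 4 (0.14 log units; that floor lies within the scatter). For compound 4 the estimated value is 120000 nM, with an expected range from 25000 nM to 300000 nM.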

Compound 4, half-maximal inhibitory concentration: 127000 nM
Estimate against measurement, compound 4: 1.1-fold (0.02 log units) below; measured number inside the range.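

In this assay, the 2,4-dichlorobenzyl group gives compound 4 a measured number rather than a limit, so a chlorinated ring on this saturated chain carbon need not sit at the limit of the assay: the limit of > 166000 nM in this assay, at which 2 of the 4 values shown sit.

Chloro in place of hydrogen on an aromatic carbon is an at least 1.3-fold lower number from compound 2 to compound 4 (0.11 log units; that floor lies within the scatter), and 2,4-dichlorophenyl in place of 3-methylphenyl is an at least 1.3-fold lower number from compound 3 to compound 4 (0.11 log units; that floor lies within the scatter); both floors lie within the scatter, so neither step establishes a real gain. Set against 3-fluorophenyl, 2,4-dichlorophenyl remains a loss, an 8.3-fold higher number from compound 1 to compound 4 (0.92 log units; beyond the scatter), and compound 1 stays the strongest of the four.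

The compounds shown leave open whether the standing of compound 1 depends on fluoro itself, or whether 3-chlorophenyl or 3-methoxyphenyl at this place would match it. They also leave open what a longer chain in place of the benzyl link would do.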